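Working notes: from compound 3 to compound 4

The source may report more compounds than this note shows. Statements on the series, on what has been measured and on what is new or still open speak of the compounds shown alone.

Values so far in a functional assay on a cell-free system (Platelet, plasma, Homo sapiens) for inhibition, with stated times of 1 min and 3 min; a higher number here means a weaker inhibitor, a lower number a stronger inhibitor
compound 1 `CCSc1nc(NCc2ccc(OC)cc2)c2ncn([C@@H]3O[C@H](CO)[C@@H](O)[C@H]3O)c2n1` gives "not determined" (no result reported)
compound 2 `CCCSc1nc(NCc2ccccc2)c2ncn([C@@H]3O[C@H](CO)[C@@H](O)[C@H]3O)c2n1` gives 216000 nM
compound 3 `CCSc1nc(NCc2ccc(C)cc2)c2ncn([C@@H]3O[C@H](CO)[C@@H](O)[C@H]3O)c2n1` gives "not determined" (no result reported)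

Going by the values given here, compound 3 has no single number in this assay and neither has compound 1, so the series offers only one number. Compound 4 `CCSc1nc(NCc2ccccc2)c2ncn([C@@H]3O[C@H](CO)[C@@H](O)[C@H]3O)c2n1` still awaits its result. The change is hydrogen in place of methyl on an aromatic carbon and amounts to hydrogen in place of methyl on an aromatic carbon, para to a large group, so that 4-methylbenzyl becomes benzyl. No measured step sizes this change. If compound 3 were given a number, no step beyond the usual scatter would be expected, in either direction. The expectation therefore rests on compound 2 alone, at 216000 nM in this assay as the only anchor. For compound 4 the estimated value is 170000 nM with an expected range from 55000 nM to 500000 nM in this series.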

Compound 4, half-maximal inhibitory concentration: 176000 nM
The estimate for compound 4 lay 1.0-fold (0.02 log units) below the measured number; the range from low to high includes it.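

In this assay, a 1.2-fold lower number from compound 2 to compound 4 (0.09 log units; within the scatter) gives this series its first measured step, at the sulfur chain rather than on the benzyl ring. With benzylamino held constant, hydrogen in place of methyl on a saturated chain carbon, two bonds along the chain from a sulfur, leaves no difference beyond the scatter. No measurement is available that explains this result.

Steps to compound 1 and compound 3 cannot be read, so the change from 4-methylbenzyl to benzyl remains unsized. As far as these compounds go, a longer chain on the sulfur, or an amine or carboxylic acid in place of that ring methyl, remains open.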